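The compounds below may be only part of what the source reports. "The series", "measured", "known", "first", "only" and "open" are said of these compounds alone.

Of the compounds shown here, three have been measured in a functional assay on UACC-62 cells (Homo sapiens) for antiproliferative activity, read by sulforhodamine B assay, with a stated time of 48 h; on this read-out higher numbers stand for weaker inhibition and lower numbers for stronger inhibition. Compound 1 `Nc1cccc2c(-c3cccc(NC(=O)c4ccc(Cl)c(C(F)(F)F)c4)c3)ccnc12` gives 2700 nM in this assay, compound 2 `Nc1cccc2c(-c3cccc(NC(=O)c4nccs4)c3)ccnc12` gives 6000 nM, and compound 3 `COc1ccc(C(=O)Nc2cccc(-c3ccnc4c(NC(C)=O)cccc34)c2)cc1OC` gives 560 nM, the lowest of the three numbers; its gap to compound 1 and its larger gap to compound 2 both lie beyond the usual scatter.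

Compound 4 `CC(=O)Nc1cccc2c(-c3cccc(NC(=O)c4ccc(Cl)c(C(F)(F)F)c4)c3)ccnc12` has not yet been measured. It differs from compound 3 in one place: 4-chloro-3-(trifluoromethyl)phenyl in place of 3,4-dimethoxyphenyl on a carbonyl carbon. Within the data shown here, no directly comparable pair among the measured compounds shows this exchange on an otherwise identical scaffold, so the size of the step is uncertain. Compound 1 carries the same 4-chloro-3-(trifluoromethyl)phenyl group on a carbonyl carbon but differs from compound 4 elsewhere, and its number sits well above that of compound 3. On that basis the step from compound 3 to compound 4 is expected to be a moderate rise, a 2.7-fold higher number from compound 3 to compound 4 (0.43 log units; beyond the scatter). Compound 4 is therefore estimated at 1500 nM in this assay, within a range of 400 nM to 5500 nM.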

Compound 4, half-maximal inhibitory concentration: 2400 nM
The estimate for compound 4 lay 1.6-fold (0.20 log units) below the measured number; low and high end bracket the measured number.
By their numbers in this assay, from the lowest: compound 3; then compounds 4 and 1 (each within the scatter of the next); then compound 2.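

Among these compounds, with the acetyl group held constant on the nitrogen on the aromatic ring, this assay gives the first direct reading of the exchange on the carbonyl carbon: 4-chloro-3-(trifluoromethyl)phenyl in place of 3,4-dimethoxyphenyl gives a 4.3-fold higher number from compound 3 to compound 4 (0.63 log units; beyond the scatter). With 4-chloro-3-(trifluoromethyl)phenyl held constant, acetyl in place of hydrogen on that nitrogen gives a 1.1-fold lower number from compound 1 to compound 4 (0.05 log units; within the scatter), so that exchange shows no readable change in this setting. Nothing available explains what lies behind either step.

The compounds shown leave open whether acetyl in place of hydrogen would be just as silent with 3,4-dimethoxyphenyl on the carbonyl carbon. They also leave open how a plain phenyl on that carbon, or a longer acyl chain such as butanoyl on the nitrogen, would read.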